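A few compounds are considered here, and "the series" means these few. Any claim that something is new, unique, unknown or untested is made for them only; others in the source may bear on it.

Measured so far:
- compound 1 `Cc1cc(C)c(NC(=O)c2sccc2S(=O)(=O)Nc2onc(C)c2Cl)c(C)c1` — 81600 nM
- compound 2 `COc1c(C)cc(C)c(NC(=O)c2sccc2S(=O)(=O)Nc2onc(C)c2Cl)c1C` — 8510 nM

In an in vivo ADME assay on the whole organism (plasma) for pharmacokinetics, with Rattus norvegicus as the target, at a dose of 50 mg/kg by the oral route (on this read-out lower numbers stand for lower exposure and higher numbers for higher exposure at the dose given), compound 1 gives 81600 nM, the higher of the two numbers; in this assay compound 2 gives 8510 nM, and the step is a 9.6-fold lower number from compound 1 to compound 2 (0.98 log units; beyond the scatter). Compound 3 `Cc1cc(C)c(NC(=O)c2sccc2S(=O)(=O)Nc2onc(C)c2Cl)c(C(=O)CS(C)(=O)=O)c1` has not been measured. Relative to compound 1, the change is ((methylsulfonyl)methyl)carbonyl in place of methyl on an aromatic carbon. Among the measured compounds shown here, no measured step covers this exact change; the only step available, a 9.6-fold lower number from compound 1 to compound 2 (0.98 log units; beyond the scatter), concerns a methoxy in place of hydrogen at a different aromatic carbon, so it bears on compound 3 only loosely, as a hint that adding a group to the ring can lower the number on this assay. A modest step downward from compound 1 is therefore expected, with wide uncertainty. For compound 3 the estimate in this assay is 30000 nM, with a range from 6000 nM to 150000 nM, meaning an expected step of a 2.7-fold lower number from compound 1 to compound 3 (0.43 log units; beyond the scatter).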

Compound 3, maximal plasma concentration: 68300 nM
Estimate against measurement, compound 3: 2.3-fold (0.36 log units) below; the measured number falls inside the stated range.
By their numbers in this assay, from the lowest: compound 2; then compounds 3 and 1 (each within the scatter of the next).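

In this assay, putting ((methylsulfonyl)methyl)carbonyl in place of methyl on this aromatic carbon gives a 1.2-fold lower number from compound 1 to compound 3 (0.08 log units; within the scatter), so the two numbers cannot be told apart. At this place, ortho to a large group and meta to two methyl groups, a chain with several more heavy atoms and three hydrogen-bond acceptors is thus compatible with exposure matching that of compound 1, and a change to this ring need not bring a step beyond the scatter like a 9.6-fold lower number from compound 1 to compound 2 (0.98 log units; beyond the scatter). No measurement at hand offers an explanation for this result.

Going by these compounds, whether an amine or a carboxylic acid on this same carbon would also match compound 1 remains open. So does the question of whether a shorter chain, such as acetyl without the methylsulfonyl end, would behave the same way.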